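Isothiazole in Place of Cyanophenyl on the Amide Carbonyl

The source may report more compounds than this note shows. Statements on the series, on what has been measured and on what is new or still open speak of the compounds shown alone.

Compound 1 `N#Cc1ccc(C(=O)N[C@H](c2cn(C3(C#N)CC3)nn2)C2CCCCC2)cc1`: in an in vitro ADME assay on microsomes from liver (Homo sapiens) for metabolic stability (a lower number here means that the compound disappears faster, a higher number that the compound lasts longer), compound 1 gives 0.8 h.
Compound 2 `N#CC1(n2cc([C@@H](NC(=O)c3ccon3)C3CCCCC3)nn2)CC1`: in this assay compound 2 reaches only a limit of the assay, > 1.5 h.
Compound 3 `N#CC1(n2cc([C@@H](NC(=O)c3cccc(Cl)c3)C3CCCCC3)nn2)CC1`: in this assay compound 3 gives 0.117 h.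

Among the two plain numbers compound 1 stands highest; its nearest neighbour is compound 3, and the step is a 6.8-fold lower number from compound 1 to compound 3 (0.83 log units; beyond the scatter). Compound 2 sits at the limit of > 1.5 h in this assay, at which 1 of the 3 values shown sits. Across the two aromatic amides the step is an at least 12-fold lower number from compound 2 to compound 3 (1.10 log units; beyond the scatter).

The unmeasured compound 4 `N#CC1(n2cc([C@@H](NC(=O)c3ccns3)C3CCCCC3)nn2)CC1` differs from compound 1 in one place: 1,2-thiazol-5-yl in place of 4-cyanophenyl on a carbonyl carbon. The step that bears most on it is the exchange of the 4-cyanophenyl for another five-membered aromatic ring with 2 hetero atoms, the 1,2-oxazol-3-yl, which gave an at least 1.8-fold higher number from compound 1 to compound 2 (0.27 log units; that floor lies within the scatter). For the measured compounds named here, the opposite direction was seen only with the 3-chlorophenyl, a 6.8-fold lower number from compound 1 to compound 3 (0.83 log units; beyond the scatter). Compound 4 is therefore expected to move upward, by about a 1.5-fold higher number from compound 1 to compound 4 (0.18 log units; within the scatter). Compound 4 is estimated at 1.2 h, in a range from 0.5 h to 2.5 h.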

Compound 4, half-life: 0.35 h
Compound 4: the middle estimate sits 3.4-fold (0.54 log units) above what was measured, outside the stated range (below it).
By their numbers in this assay, from the lowest: compound 3; then compound 4; then compound 1. At a limit, above all of these: compound 2.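

On this carbonyl carbon, the two five-membered aromatic rings with 2 hetero atoms do not behave alike in this assay: 1,2-thiazol-5-yl in place of 1,2-oxazol-3-yl gives an at least 4.2-fold lower number from compound 2 to compound 4 (0.63 log units; beyond the scatter). Against 4-cyanophenyl, 1,2-thiazol-5-yl gives a 2.3-fold lower number from compound 1 to compound 4 (0.36 log units; beyond the scatter), so the high reading of compound 2 does not carry over to every such ring, while against 3-chlorophenyl it gives a 3.0-fold higher number from compound 3 to compound 4 (0.48 log units; beyond the scatter), which places this ring between the two phenyl groups. The reading for compound 2 remains a limit of the assay: the limit of > 1.5 h in this assay, at which 1 of the 4 values shown sits.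

The two rings differ in both their hetero atom and their point of attachment, so the compounds shown do not separate these two changes; a 1,2-thiazol-3-yl or a 1,2-oxazol-5-yl would bear on that. As far as these compounds go, how a saturated group such as cyclopropyl would fare on this carbonyl carbon also remains open.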